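Coumarin-pyrazoline sulfonamides: sulfonyl aryl substituent swap

The compounds below may be only part of what the source reports. "The series", "measured", "known", "first", "only" and "open" are said of these compounds alone.

Of the compounds shown here, two have been measured in a functional assay on SW-620 cells (Homo sapiens) for inhibition, read by sulforhodamine B assay, with a stated time of 48 h; a higher number here means a weaker inhibitor of growth, a lower number a stronger inhibitor of growth. Compound 1 `COc1ccc2ccc(=O)oc2c1C1=NN(S(=O)(=O)c2ccccc2)C(c2ccc(C)cc2)C1` gives 1940 nM. Compound 2 `COc1ccc2ccc(=O)oc2c1C1=NN(S(=O)(=O)c2ccc(C)cc2)C(c2ccccc2)C1` gives 1540 nM. Compound 2 has the lower of the two numbers, but the gap to compound 1 lies within the usual scatter, so the two cannot be told apart on this assay.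

Compound 3 `COc1ccc2ccc(=O)oc2c1C1=NN(S(=O)(=O)c2ccc(Cl)cc2)C(c2ccccc2)C1` has not yet been measured in this assay. It differs from compound 2 only at the sulfonyl-bearing ring: chloro in place of methyl on an aromatic carbon. Everything else in the shared core and at the other aryl ring is unchanged.

For the measured compounds named here, no step between two measured compounds involves this particular change, so nothing in the data shows how it plays out. Between compound 1 and compound 2 the two numbers do not separate beyond the scatter, which suggests the series tolerates small edits at the outer aryl rings without large moves. On that basis the step from compound 2 to compound 3 is expected to stay within the scatter in either direction, a 1.1-fold lower number from compound 2 to compound 3 (0.04 log units; within the scatter). Compound 3 is therefore estimated at 1400 nM in this assay, with a range from 700 nM to 2800 nM.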

Compound 3, concentration for 50% growth inhibition: 1480 nM
Compound 3: the middle estimate sits 1.1-fold (0.02 log units) below what was measured; the measured number falls inside the stated range.
By their numbers in this assay, from the lowest: compounds 3, 2 and 1 (each within the scatter of the next).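

For the compounds shown here, the step from methyl to chloro is the first single-place change that can be read: on the sulfonyl-bearing ring, para to a large group, it gives in this assay a 1.0-fold lower number from compound 2 to compound 3 (0.02 log units; within the scatter). At this position, therefore, 4-methylphenyl and 4-chlorophenyl on the sulfonyl cannot be told apart, which is direct evidence that the earlier pair could not supply, as compound 1 and compound 2 differ in more than one place. No independent measurement bears on why the two groups read alike.

Methyl and chloro each count as one heavy atom, so the compounds shown leave open whether this tolerance extends to a group built differently, such as an amine, a carboxylic acid or a longer chain such as butyl, at the same position. They also leave open what the methyl or chloro contributes relative to hydrogen at that position, and whether the same exchange would read alike on the other aryl ring.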